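Acetamide in place of methanesulfonamide on the urea aryl

The compounds below may be only part of what the source reports. "The series", "measured", "known", "first", "only" and "open" are said of these compounds alone.

Compound 3 `CS(=O)(=O)Nc1ccc(NC(=O)Nc2cccc(-c3nc(-c4ccc(NC(=O)c5cccnc5)cc4Cl)no3)c2)cc1` gives 600 nM in a functional assay on MDA-MB-231 cells (Homo sapiens) for antiproliferative activity, read by MTT assay, with a stated time of 72 h (on this read-out lower numbers stand for stronger inhibition and higher numbers for weaker inhibition), the lowest of the two numbers shown for the series. Compound 1 `NS(=O)(=O)Nc1ccc(NC(=O)Nc2cccc(-c3nc(-c4ccc(NC(=O)c5cccnc5)cc4Cl)no3)c2)cc1` gives 8900 nM, and the change a 15-fold lower number from compound 1 to compound 3 (1.17 log units; beyond the scatter) is the nearest comparison. Compound 2 `CS(=O)(=O)Nc1cccc(NC(=O)Nc2cccc(-c3nc(-c4ccc(NC(=O)c5cccnc5)cc4Cl)no3)c2)c1` reaches only a limit, > 10000 nM, the floor noted as the limit of > 10000 nM in this assay, at which 1 of the 3 values shown sits. The step of an at least 16-fold lower number from compound 2 to compound 3 (1.22 log units; beyond the scatter) supports the 4-(methanesulfonamido)phenyl arrangement over its alternative. Compound 4 `CC(=O)Nc1ccc(NC(=O)Nc2cccc(-c3nc(-c4ccc(NC(=O)c5cccnc5)cc4Cl)no3)c2)cc1` keeps that arrangement and applies (acetyl in place of methylsulfonyl on a nitrogen on an aromatic ring). For the measured compounds named here, no measured pair swaps methylsulfonyl for acetyl; the single step at the same nitrogen, a 15-fold lower number from compound 1 to compound 3 (1.17 log units; beyond the scatter), shows that the group there shifts the number strongly, so a step beyond the scatter in either direction is plausible, with weakening taken as the likelier outcome. Compound 4 is therefore expected at 1800 nM, range 400 nM to 8000 nM, a step of a 3.0-fold higher number from compound 3 to compound 4 (0.48 log units; beyond the scatter).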

Compound 4, half-maximal inhibitory concentration: > 10000 nM
Compound 4: a limit, no number; the forecaster's own chance of this, stated with the estimate: 10%; at least 5.5-fold (0.74 log units) between middle value and limit.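

In this assay the low number of compound 3 depends on methylsulfonyl on this nitrogen, and acetyl does not replace it (an at least 16-fold higher number from compound 3 to compound 4 (1.22 log units; beyond the scatter)); the entry for compound 4 is only a limit. Against sulfamoyl, acetyl shows no readable change (an at least 1.1-fold higher number from compound 1 to compound 4 (0.05 log units; that floor lies within the scatter)), so among these three groups only methylsulfonyl keeps the number low. The step from compound 2 to compound 4 cannot be read, since both entries are limits: the limit of > 10000 nM in this assay, at which 2 of the 4 values shown sit.

From the compounds shown here alone, whether the need extends beyond methylsulfonyl stays open: ethylsulfonyl or trifluoromethylsulfonyl on the same nitrogen would test it. A free amine in place of the whole methanesulfonamido group is equally untested among the compounds shown.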